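Two Methylfurans, One Open Number

The source may report more compounds than this note shows. Statements on the series, on what has been measured and on what is new or still open speak of the compounds shown alone.

In a physicochemical assay for lipophilicity, read by HPLC, with a stated time of 90 min, tested at 100 uM (a higher number here means a more lipophilic compound, a lower number a more polar compound), compound 2 `Cc1occc1C(=O)N1CCC(NC(=O)Nc2ccc(C(F)(F)F)cc2)CC1` gives 4.19. Compound 3 `Cc1occc1C(=O)N1CCC(NC(=O)Nc2ccc(OC(F)(F)F)cc2)CC1` gives 4.3, within the scatter of compound 2. Compound 1 `O=C(Nc1ccc(C(F)(F)F)cc1)NC1CCN(C(=O)C2CCCOC2)CC1` gives 3.41, clearly lower than both.

Compound 4 `Cc1ccoc1C(=O)N1CCC(NC(=O)Nc2ccc(C(F)(F)F)cc2)CC1` differs from compound 2 in one place: 3-methylfuran-2-yl in place of 2-methylfuran-3-yl on a carbonyl carbon. Here 3-methylfuran-2-yl stands in place of 2-methylfuran-3-yl on a carbonyl carbon, so the two compounds have the same atoms, joined differently.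

Two measured steps offer some guidance. The step at that same carbonyl carbon, 2-methylfuran-3-yl in place of oxan-3-yl, was a number 0.78 log units higher from compound 1 to compound 2 (beyond the scatter). This shows that a change in this place can move the number, but it exchanges one kind of ring for another. The second step, trifluoromethoxy in place of trifluoromethyl on an aromatic carbon, was a number 0.11 log units higher from compound 2 to compound 3 (within the scatter). Neither step tests a swap between two methylfuran groups, so the evidence is indirect.

With the counted atoms unchanged, no step beyond the scatter is expected in this assay, and the estimated change is a number 0.04 log units lower from compound 2 to compound 4 (within the scatter). Compound 4 is expected at about 4.15, with an estimated range from 3.8 to 4.5.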

Compound 4, partition coefficient: 4.29
Compound 4: the middle estimate sits 0.14 log units below what was measured, within the range that was stated.
By their numbers in this assay, from the lowest: compound 1; then compounds 2, 4 and 3 (each within the scatter of the next).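

Swapping one methylfuran for the other at this carbonyl carbon, with the same atoms joined differently, gives a number 0.10 log units higher from compound 2 to compound 4 (within the scatter) in this assay. For this pair, then, rearranging the methyl group and the furan attachment does not produce a step beyond the scatter. The earlier compounds shown here could not provide this result. None of them compared two methylfuran groups directly. The second methylfuran also gives a number 0.88 log units higher from compound 1 to compound 4 (beyond the scatter) when it stands in place of oxan-3-yl, so a step beyond the scatter from oxan-3-yl now appears with both methylfuran groups rather than with 2-methylfuran-3-yl alone, although no measurement shown here bears on what lies behind these numbers.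

The compounds shown pair 3-methylfuran-2-yl only with trifluoromethyl, so its number alongside trifluoromethoxy remains an open question. Also open, on these data alone, is how the number would respond at this carbonyl carbon to a group carrying an amine or a carboxylic acid, or to a plain furan without the methyl group.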